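This account rests on a few compounds, and the source may have more. Where it says the series, first, only, none or still open, it means among the compounds named here.

All four compounds share one core, seen in compound 1 `O=C(N/N=C/c1cccnc1)c1ccc(-c2nc3ccccc3s2)cc1`, and differ only in the aromatic group attached to the carbon that carries a double bond to nitrogen. In an assay on isolated protein for inhibition of Maltase-glucoamylase (Homo sapiens), with a stated time of 15 min (on this read-out higher numbers stand for weaker inhibition and lower numbers for stronger inhibition), compound 1 gives "not active" (no number reported). Compound 2 `O=C(N/N=C/c1ccc(O)cc1O)c1ccc(-c2nc3ccccc3s2)cc1`, which carries two hydroxyl groups on that ring, is the only one of the three measured compounds with a number: in this assay compound 2 gives 5580 nM. Compound 3 `COC(=O)c1ccc(/C=N/NC(=O)c2ccc(-c3nc4ccccc4s3)cc2)cc1` carries a methoxycarbonyl group instead, and in this assay compound 3 gives "not active" (no number reported), so no single number is known for it, and it stands alongside compound 1 rather than compound 2.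

Compound 4 `O=C(N/N=C/c1ccc(F)c(Br)c1)c1ccc(-c2nc3ccccc3s2)cc1` is reached from compound 3 by one change: 3-bromo-4-fluorophenyl in place of 4-(methoxycarbonyl)phenyl on a carbon with a double bond to nitrogen. Within the data shown here, no measured pair shows what such a change does in this assay, so the size of the step cannot be read from the data. Since compound 1 and compound 3 both lack a number and only compound 2 shows weak inhibition, compound 4 is expected to be weak as well, with an estimated value of 25000 nM and a range from 6000 nM to 100000 nM.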

Compound 4, half-maximal inhibitory concentration: 28000 nM
Estimate against measurement, compound 4: 1.1-fold (0.05 log units) below; the range from low to high includes it.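

Compound 4 shows that this position does not need hydroxyl groups for a number to appear in this assay, since a ring carrying bromine and fluorine also gives measurable, though weak, inhibition. Putting 3-bromo-4-fluorophenyl in place of 2,4-dihydroxyphenyl on a carbon with a double bond to nitrogen gives a 5.0-fold higher number from compound 2 to compound 4 (0.70 log units; beyond the scatter), so compound 2 remains the stronger of the two inhibitors. Steps from compound 1 or compound 3 cannot be read, as neither compound has a number. Nothing measured here explains the difference between these two groups. Still open, on these data alone, is whether bromine or fluorine alone would give a similar value, and whether a single hydroxyl group would match the two in compound 2. An amine or a carboxylic acid on this ring also remains untested in the compounds shown here.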